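Replacing the 2-chloro-5-methylphenyl group of compound 2

The source may report more compounds than this note shows. Statements on the series, on what has been measured and on what is new or still open speak of the compounds shown alone.

Compound 1 `Cc1ccc(Cl)cc1-n1nnc(C(=O)Nc2ccc(SC#N)cc2)c1C` gives 9900 nM
Compound 2 `Cc1ccc(Cl)c(-n2nnc(C(=O)Nc3ccc(SC#N)cc3)c2C)c1` gives 100000 nM

In a functional assay on BALB/3T3 cells (Mus musculus) for antiproliferative activity, read by MTT assay, with a stated time of 72 h (a lower number here means a stronger inhibitor of growth, a higher number a weaker inhibitor of growth), compound 2 gives 100000 nM as the higher of the two numbers. Compound 3 `COc1cccc(-n2nnc(C(=O)Nc3ccc(SC#N)cc3)c2C)c1` carries 3-methoxyphenyl in place of 2-chloro-5-methylphenyl on an aromatic nitrogen and is still unmeasured. For the measured compounds named here, only one measured step bears on this change, a swap on that same nitrogen, which gave a 10-fold higher number from compound 1 to compound 2 (1.00 log units; beyond the scatter) as a modest shift. Going by the values given here, no measured compound carries a methoxy group, so a step of similar or smaller size toward a lower number is expected. The expected change is a 3.3-fold lower number from compound 2 to compound 3 (0.52 log units; beyond the scatter) by this estimate. The estimate for compound 3 is 30000 nM with 8000 nM to 100000 nM as its expected range.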

Compound 3, concentration for 50% growth inhibition: > 100000 nM
Compound 3: a limit, no number; the forecaster's own chance of this, stated with the estimate: 20%; middle value at least 3.3-fold (0.52 log units) from the limit.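

Compound 3 gives a limit and not a number: the limit of > 100000 nM in this assay, at which 1 of the 3 values shown sits. Against the 2-chloro-5-methylphenyl group there is a number no lower from compound 2 to compound 3 (the limit leaves the size open), so the size of this step cannot be read. For the compounds shown here, the one readable step is an at least 10-fold higher number from compound 1 to compound 3 (1.00 log units; beyond the scatter), so 3-methoxyphenyl on this nitrogen does not bring back the lower number seen with 5-chloro-2-methylphenyl.

The compounds shown leave open how far a group on this phenyl ring can lower the number. Whether an amine or a carboxylic acid in place of the methoxy group would do so remains an open question.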